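Swapping the sulfonyl aryl group and the cytotoxicity expected

The source may report more compounds than this note shows. Statements on the series, on what has been measured and on what is new or still open speak of the compounds shown alone.

Compounds measured so far in an ADME assay on HEK293 cells (Homo sapiens) for cytotoxicity, read by resazurin assay, with a stated time of 48 h; on this read-out lower numbers stand for higher toxicity in this test and higher numbers for lower toxicity in this test:
Compound 1 `O=S(=O)(Nc1ccc2oc(-c3ccccc3)nc2c1)c1cccc(F)c1` gives 68000 nM.
Compound 2 `O=S(=O)(Nc1ccc2oc(-c3ccccc3)nc2c1)c1ccccc1F` gives 72000 nM.

Within the data shown here, compound 2 stands on one of only two numbers, and these two lie within the scatter of each other, so neither can be called more or less toxic than the other. Among the measured compounds shown here, the single measured step, a 1.1-fold higher number from compound 1 to compound 2 (0.02 log units; within the scatter), shows that moving the fluorine around the ring on the sulfonyl sulfur made no difference beyond the scatter.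

Compound 3 `COc1ccc(Cl)cc1S(=O)(=O)Nc1ccc2oc(-c3ccccc3)nc2c1` is the next compound, not yet measured in this assay. It differs from compound 2 in one place: 5-chloro-2-methoxyphenyl in place of 2-fluorophenyl on a sulfonyl sulfur. For the measured compounds named here, no measured step covers this kind of change; the only step available, from compound 1 to compound 2, concerns a small shift of one fluorine and is within the scatter, so it gives little guidance beyond suggesting that the aryl group on the sulfonyl sulfur has so far not moved the cytotoxicity.

The expected step is therefore a 1.2-fold lower number from compound 2 to compound 3 (0.08 log units; within the scatter), within the scatter. Compound 3 is estimated at 60000 nM, with a range from 25000 nM to 140000 nM.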

Compound 3, half-maximal cytotoxic concentration: 74000 nM
Estimate against measurement, compound 3: 1.2-fold (0.09 log units) below; measured number inside the range.
By their numbers in this assay, from the lowest: compounds 1, 2 and 3 (each within the scatter of the next).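

In this assay, the earlier pair only moved one fluorine around the ring, whereas compound 3 brings a different and larger aryl group, 5-chloro-2-methoxyphenyl, onto the sulfonyl sulfur. Even so, the result is a 1.0-fold higher number from compound 2 to compound 3 (0.01 log units; within the scatter), and against the other fluorinated compound it is a 1.1-fold higher number from compound 1 to compound 3 (0.04 log units; within the scatter), so this place on the sulfonyl sulfur has now taken a group with chlorine and oxygen atoms without any shift beyond the scatter. No separate measurement is available to explain this flat result.

The compounds shown leave open whether the chlorine and the methoxy group each leave the number unchanged when present alone, as the two enter together here and could in principle offset each other. They also leave open whether the flat picture would hold with something quite unlike these uncharged aryl groups on the sulfonyl sulfur, such as a ring carrying an amine or a carboxylic acid, or a longer alkyl chain in place of the ring.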